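Swapping the ring on the thiocarbonyl carbon of compound 2

A few compounds are considered here, and "the series" means these few. Any claim that something is new, unique, unknown or untested is made for them only; others in the source may bear on it.

Three compounds share a thiosemicarbazide-like core that ends in a saturated ring on the thiocarbonyl carbon. Compound 1 `Cc1ccnc(/C(N)=N/NC(=S)N2CCCC2)c1` gives 87.9% in a functional assay on A-375 cells (Homo sapiens) for cytotoxicity, read by MTT assay, with a stated time of 72 h, tested at 30 uM; on this read-out lower numbers stand for less inhibition of growth and higher numbers for more inhibition of growth at the one concentration tested. Compound 3 `N/C(=N\NC(=S)N1CCCCC1)c1ccccn1` gives 87%. Compound 2 `Cc1cccc(/C(N)=N/NC(=S)N2CCCCC2)n1` gives 80.9%. Compound 2 shows the smallest of the three numbers, but the differences to compound 1 and compound 3 both lie within the usual scatter of this assay, so the three are best read as alike. Among the measured compounds shown here, the only measured step between neighbours, hydrogen in place of methyl on an aromatic carbon, gives a number 6.1 percentage points higher from compound 2 to compound 3 (within the scatter).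

Compound 4 `Cc1cccc(/C(N)=N/NC(=S)N2CCSCC2)n1` is not yet measured. It differs from compound 2 in one place: thiomorpholin-4-yl in place of piperidin-1-yl on a thiocarbonyl carbon. For the measured compounds named here, no measured step changes the ring on the thiocarbonyl carbon, so nothing directly comparable exists; the one measured step concerns a different part of the molecule and is itself within the scatter. With all three known numbers close together, the expectation is a step of a number 0.9 percentage points lower from compound 2 to compound 4 (within the scatter), that is, no change beyond the scatter. Compound 4 is therefore estimated at 80% in this assay, with a range from 68% to 92%.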

Compound 4, percent growth inhibition at one concentration: 73.1%
Compound 4: middle estimate off by 6.9 percentage points, on the high side, within the range that was stated.
By their numbers in this assay, from the lowest: compounds 4, 2, 3 and 1 (each within the scatter of the next, the first and the last beyond it).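

Among the compounds shown here, putting thiomorpholin-4-yl in place of piperidin-1-yl on a thiocarbonyl carbon gives the only measured change to this ring, and in this assay it amounts to a number 7.8 percentage points lower from compound 2 to compound 4 (within the scatter) and so does not separate the two compounds. The earlier step concerned only a methyl group on an aromatic carbon, so this pair adds the first sign that the ring on the thiocarbonyl carbon can also change without a shift beyond the scatter, even though a ring carbon gives way to sulfur and the count of hydrogen-bond acceptors goes from 0 to 1. The data offer no measurement that could explain the size of this step, or show what the sulfur itself contributes.

This is a single pair tested at one concentration, so it cannot show whether the same exchange would leave the numbers alike on the core of compound 3, which lacks the methyl group, or at lower concentrations. Going by these compounds, it also remains open how this position would respond to a morpholin-4-yl ring with oxygen in place of sulfur, a piperazin-1-yl ring with a second ring nitrogen, or an open-chain dimethylamino group.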